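Difluorophenyl in place of hydroxyphenyl on the shared core

The source may hold more compounds than are shown below. What is called first, only, known or untested is meant among the compounds shown, and "the series" means these compounds.

Of the compounds shown here, three sharing one core have been measured in a functional assay on KB-VIN10 cells (Homo sapiens) for inhibition, with a stated time of 72 h; a lower number here means a stronger inhibitor, a higher number a weaker inhibitor. Compound 1 `COc1ccc(S(=O)(=O)N2CCc3cccc(-c4cccnc4)c32)cc1` gives 84.5 nM. Compound 2 `COc1ccc(S(=O)(=O)N2CCc3cccc(-c4ccc(C#N)cc4)c32)cc1` gives 29.2 nM, and compound 3 `COc1ccc(S(=O)(=O)N2CCc3cccc(-c4ccc(O)cc4)c32)cc1` gives 123 nM. Compound 3 therefore shows the highest number of the three; its nearest neighbour is compound 1, a gap within the scatter, and its furthest is compound 2, with a 4.2-fold higher number from compound 2 to compound 3 (0.62 log units; beyond the scatter).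

Compound 4 `COc1ccc(S(=O)(=O)N2CCc3cccc(-c4ccc(F)c(F)c4)c32)cc1` differs from compound 3 in one place: 3,4-difluorophenyl in place of 4-hydroxyphenyl on an aromatic carbon. The measured steps that bear on this change are a 1.5-fold higher number from compound 1 to compound 3 (0.16 log units; within the scatter) and a 4.2-fold higher number from compound 2 to compound 3 (0.62 log units; beyond the scatter), both ending at compound 3 and both describing changes of the group at the same aromatic carbon. For the measured compounds named here, no measured step covers fluorine on that ring, so what is known is only that swapping the hydroxy group for other groups gave numbers at or below that of compound 3.

Compound 4 is therefore expected to show a lower number than compound 3, with a 2.5-fold lower number from compound 3 to compound 4 (0.39 log units; beyond the scatter) as the estimated step, in this assay. The value for compound 4 is estimated at 50 nM, within a range of 18 nM to 140 nM.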

Compound 4, half-maximal inhibitory concentration: 46 nM
Compound 4: middle estimate off by 1.1-fold (0.04 log units), on the high side, within the range that was stated.
By their numbers in this assay, from the lowest: compounds 2, 4, 1 and 3 (each within the scatter of the next, the first and the last beyond it).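

In this assay, the position tolerates a ring with no hydrogen-bond donor or acceptor: exchanging 4-hydroxyphenyl for 3,4-difluorophenyl gives a 2.7-fold lower number from compound 3 to compound 4 (0.43 log units; beyond the scatter) and so shows that the hydroxy group is not required for a low number here. The difluorophenyl ring also cannot be told apart from the other two rings, with a 1.6-fold higher number from compound 2 to compound 4 (0.20 log units; within the scatter) against 4-cyanophenyl and a 1.8-fold lower number from compound 1 to compound 4 (0.26 log units; within the scatter) against pyridin-3-yl, so the hydroxy compound is clearly separated only from the cyano and difluoro compounds and not from the pyridine compound. No measurement shown here explains the difference between these rings.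

The compounds shown leave open whether both fluorine atoms are needed, as no ring carrying only one of them appears. Nor do they show how a ring bearing an amine or a carboxylic acid would behave at this position.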